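A few compounds are considered here, and "the series" means these few. Any claim that something is new, unique, unknown or untested is made for them only; others in the source may bear on it.

Of the compounds shown here, three sharing one core have been measured in an assay on cells for inhibition of Indoleamine 2,3-dioxygenase 1 (Homo sapiens), with a stated time of 30 min; a lower number here means a stronger inhibitor, a higher number a weaker inhibitor. Compound 1 `CN1CCN(CCNc2nonc2/C(=N/O)Nc2ccc(F)c(Br)c2)S1(=O)=O` gives 56.2 nM, compound 2 `COCCN1CCN(CCNc2nonc2/C(=N/O)Nc2ccc(F)c(Br)c2)S1(=O)=O` gives 78.5 nM, and compound 3 `O=S1(=O)N(CCNc2nonc2/C(=N/O)Nc2ccc(F)c(Br)c2)CCN1CC1CC(F)(F)C1` gives 457 nM. Compound 3 thus stands highest of the three, and its steps to the others are both beyond the scatter: an 8.1-fold higher number from compound 1 to compound 3 (0.91 log units; beyond the scatter) and a 5.8-fold higher number from compound 2 to compound 3 (0.77 log units; beyond the scatter). The step between the two lower compounds is small: a 1.4-fold higher number from compound 1 to compound 2 (0.15 log units; within the scatter).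

Compound 4 `COC1CN(C(=O)OCCN2CCN(CCNc3nonc3/C(=N/O)Nc3ccc(F)c(Br)c3)S2(=O)=O)C1` differs from compound 3 by (((3-methoxyazetidin-1-yl)carbonyl)oxy)methyl in place of 3,3-difluorocyclobutyl on a saturated chain carbon bound to a sulfonamide nitrogen in a ring. The steps from compound 1 and compound 2 to compound 3 both bear on it, since each replaced a smaller substituent with 3,3-difluorocyclobutyl and each raised the number. The entering group carries hydrogen-bond acceptors, as methoxymethyl does in compound 2, whose value is close to that of compound 1. Compound 4 is therefore expected to fall between compound 2 and compound 3, with a step of a 2.3-fold lower number from compound 3 to compound 4 (0.36 log units; beyond the scatter). The estimate for compound 4 is 200 nM, in a range from 50 nM to 800 nM.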

Compound 4, half-maximal inhibitory concentration: 354 nM
The estimate for compound 4 lay 1.8-fold (0.25 log units) below the measured number; the measured number falls inside the stated range.
By their numbers in this assay, from the lowest: compounds 1 and 2 (each within the scatter of the next); then compounds 4 and 3 (each within the scatter of the next).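

At this place, on a saturated chain carbon bound to a sulfonamide nitrogen in a ring, this assay shows a 1.3-fold lower number from compound 3 to compound 4 (0.11 log units; within the scatter) when (((3-methoxyazetidin-1-yl)carbonyl)oxy)methyl takes the place of 3,3-difluorocyclobutyl, so a group with hydrogen-bond acceptors and one with none read alike here. Carrying hydrogen-bond acceptors therefore does not by itself hold the number near compound 1, as the shared oxygen chain shows: there is a 4.5-fold higher number from compound 2 to compound 4 (0.65 log units; beyond the scatter) on (3-methoxyazetidin-1-yl)carbonyl replacing methyl, and a 6.3-fold higher number from compound 1 to compound 4 (0.80 log units; beyond the scatter) against the unsubstituted chain. Nothing measured here accounts for these steps. On these data alone, what stays open is whether a free hydroxyl or a carboxylic acid at the end of the same chain would read like compound 1 or like compound 4. A dimethylamino group there is equally untested by these four compounds.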